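A few compounds are considered here, and "the series" means these few. Any claim that something is new, unique, unknown or untested is made for them only; others in the source may bear on it.

Working notes on the series. Compound 1 `N#Cc1cccc(S(=O)(=O)c2cnc3c(F)cccc3c2-c2cccc(Cl)c2)c1` and compound 2 `O=S(=O)(c1cccc(F)c1)c1cnc2c(F)cccc2c1-c1ccc(Cl)cc1` have been run in an ADME assay on microsomes from liver (Homo sapiens) for metabolic stability, tested at 2.5 uM; a lower number here means slower removal, a higher number faster removal of the compound. In this assay, within the data shown here, compound 1 gives 1.11 mL/min and compound 2 gives 0.62 mL/min; the two numbers lie within the scatter of each other, so no order between them can be read, and compound 2 simply carries the lower of the two numbers so far. Compound 3 `N#Cc1cccc(S(=O)(=O)c2cnc3c(F)cccc3c2-c2ccc(Cl)cc2)c1` has not yet been measured in this assay. It differs from compound 2 in one place: cyano in place of fluoro on an aromatic carbon.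

No measured step covers this change, so expectation rests on the two numbers shown. Compound 1, which carries the 3-cyanophenyl group, gives 1.11 mL/min, close to compound 2; a step of at most moderate size, if any, is expected, with a slight lean upward. Compound 3 is expected to show 0.85 mL/min, within 0.45 mL/min to 1.6 mL/min. The expected step from compound 2 is a 1.4-fold higher number from compound 2 to compound 3 (0.14 log units; within the scatter).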

Compound 3, intrinsic clearance in a liver preparation (reported as CLH), per the amount of preparation that the assay uses: 0.08 mL/min
The estimate for compound 3 lay 11-fold (1.03 log units) above the measured number, and the stated range ends above it.
By their numbers in this assay, from the lowest: compound 3; then compounds 2 and 1 (each within the scatter of the next).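

In this assay, the 3-fluorophenyl to 3-cyanophenyl change gives a 7.8-fold lower number from compound 2 to compound 3 (0.89 log units; beyond the scatter) with the 4-chlorophenyl group held constant, so this position can strongly affect the read-out. Among these compounds, the 3-cyanophenyl group does not set the number alone: with it held constant, 4-chlorophenyl in place of 3-chlorophenyl gives a 14-fold lower number from compound 1 to compound 3 (1.14 log units; beyond the scatter) as the largest step so far, which shows that the chlorine placement matters as well. Nothing available accounts for either step.

As far as these compounds go, it remains open whether the cyano-for-fluoro step keeps its size when 3-chlorophenyl replaces 4-chlorophenyl, which would show whether the two places act independently. From the compounds shown here alone, it is also open whether groups such as an amine, a carboxylic acid or a methoxy at this position would give a similarly low number.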